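A few compounds are considered here, and "the series" means these few. Any claim that something is new, unique, unknown or untested is made for them only; others in the source may bear on it.

Compound 3 `CC1(C)[C@H]2CC[C@]1(C)N(Cc1cn(-c3ccc(Br)cc3)nn1)C(=O)C2` gives 80 nM in a functional assay on A549 cells (Homo sapiens) for inhibition, read by MTT assay, with a stated time of 24 h (a higher number here means a weaker inhibitor, a lower number a stronger inhibitor), a number that sits alongside those of the two other measured compounds: compound 1 `CC1(C)[C@H]2CC[C@]1(C)N(Cc1cn(-c3ccc(Cl)cc3)nn1)C(=O)C2` gives 70 nM and compound 2 `Cc1ccccc1-n1cc(CN2C(=O)C[C@@H]3CC[C@@]2(C)C3(C)C)nn1` gives 90 nM, with steps of a 1.1-fold higher number from compound 1 to compound 3 (0.06 log units; within the scatter) and a 1.1-fold lower number from compound 2 to compound 3 (0.05 log units; within the scatter). Compound 4 `Cc1cccc(-n2cc(CN3C(=O)C[C@@H]4CC[C@@]3(C)C4(C)C)nn2)c1` carries 3-methylphenyl in place of 4-bromophenyl on an aromatic nitrogen. Two measured steps also exchange the group on that aromatic nitrogen: a 1.3-fold higher number from compound 1 to compound 2 (0.11 log units; within the scatter) and a 1.1-fold lower number from compound 2 to compound 3 (0.05 log units; within the scatter), both within the scatter, so changing this aryl group has so far left this assay unmoved. The step is therefore expected to be a 1.1-fold higher number from compound 3 to compound 4 (0.03 log units; within the scatter), with no direction beyond the scatter. Compound 4 is estimated at 85 nM, with a range from 45 nM to 170 nM.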

Compound 4, half-maximal inhibitory concentration: 50 nM
Beside the measured number, compound 4's estimate is 1.7-fold (0.23 log units) above it, and the stated range covers the measured number.
By their numbers in this assay, from the lowest: compounds 4, 1, 3 and 2 (each within the scatter of the next).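

In this assay, the 3-methylphenyl group stays within the scatter of all three other aryl groups: a 1.6-fold lower number from compound 3 to compound 4 (0.20 log units; within the scatter), a 1.8-fold lower number from compound 2 to compound 4 (0.26 log units; within the scatter) and a 1.4-fold lower number from compound 1 to compound 4 (0.15 log units; within the scatter). Across these four compounds, neither a halogen nor a methyl group on the phenyl ring, at any of the ring placements shown, separates one compound from another. No measurement shown offers an explanation for this result. From the compounds shown here alone, whether an amine or a carboxylic acid on the phenyl ring, or a pyridine ring in its place, would produce a step beyond the scatter remains open.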